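A few compounds are considered here, and "the series" means these few. Any claim that something is new, unique, unknown or untested is made for them only; others in the source may bear on it.

Measured in a functional assay on L1210 cells (Mus musculus) for inhibition; on this read-out lower numbers stand for stronger inhibition and higher numbers for weaker inhibition:

- Compound 1 `C=Cc1cc(=O)[nH]c(=O)n1C1O[C@H](CO)[C@@H](O)[C@H]1O`: 12000 nM
- Compound 2 `C/C=C/c1cc(=O)[nH]c(=O)n1C1O[C@H](CO)[C@@H](O)[C@H]1O`: > 35000 nM, a limit
- Compound 3 `CCOC(=O)/C(C)=C/c1cc(=O)[nH]c(=O)n1C1O[C@H](CO)[C@@H](O)[C@H]1O`: > 30000 nM, a limit

Only compound 1 yields a true number in this assay. Compound 3 yields only a limit, > 30000 nM. On these data alone, its exact place therefore remains unknown, and a step that the two limits leave unreadable from compound 2 to compound 3 cannot be sized.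

The next compound to be tested is compound 4 `COC(=O)/C(Br)=C\c1cc(=O)[nH]c(=O)n1C1O[C@H](CO)[C@@H](O)[C@H]1O`. It carries 2-bromo-2-(methoxycarbonyl)ethenyl in place of 2-(ethoxycarbonyl)prop-1-en-1-yl on an aromatic carbon. Among the compounds with values here, no measured step makes this exact exchange, so the evidence is indirect. The closest guide is an at least 2.5-fold higher number from compound 1 to compound 3 (0.39 log units; beyond the scatter), and an at least 2.9-fold higher number from compound 1 to compound 2 (0.46 log units; beyond the scatter) points the same way. Both steps replace vinyl with a larger side chain, and both move to weaker inhibition, beyond the scatter.

Compound 4 also carries a larger side chain than vinyl, so it is expected to sit nearer compound 3 than compound 1, although the bromine is new to this small series. No clear step is expected, and the limit on compound 3 leaves any expected size uncertain. The expected change is a number no higher from compound 3 to compound 4 (the limit leaves the size open). The estimate for compound 4 is 30000 nM, with an expected range from 8000 nM to 60000 nM.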

Compound 4, half-maximal inhibitory concentration: > 25000 nM
Compound 4: no number, only a limit; the forecaster's own chance of this, stated with the estimate: 55%; the middle value lies beyond the limit too.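

In this assay compound 4 gives only a limit, > 25000 nM. Within the data shown here, replacing vinyl with 2-bromo-2-(methoxycarbonyl)ethenyl at this position next to the ring nitrogen gives an at least 2.0-fold higher number from compound 1 to compound 4 (0.31 log units; beyond the scatter), so a third larger side chain, and the first to carry bromine, also goes with weaker inhibition than vinyl, which remains the only group here with a true number. The steps linking compound 4 to compound 2 and compound 3 cannot be read, because compound 4, like those two, gives only a limit: the limit of > 25000 nM in this assay, at which 1 of the 4 values shown sits.

The compounds shown leave open how weak compound 2, compound 3 and compound 4 really are, and therefore whether the bromine or the ester in compound 4 changes anything relative to the other two side chains. Also open, on these data alone, is whether any other group at this position could match or improve on vinyl, for example a simple ethyl chain, an amine such as aminomethyl, or a carboxylic acid in place of the ester on the ethenyl side chain.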